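The source may hold more compounds than are shown below. What is called first, only, known or untested is meant among the compounds shown, and "the series" means these compounds.

Measured compounds:
Compound 1, `CCCC/C(Nc1ccc(CN2CCCCC2)cc1)=C1/C(=O)Nc2ccc(NS(=O)(=O)CC)cc21`: in an ADME assay on HepG2 cells (Homo sapiens) for cytotoxicity, read by MTT assay, with a stated time of 48 h (on this read-out higher numbers stand for lower toxicity in this test and lower numbers for higher toxicity in this test), compound 1 gives > 6 uM, which is a limit of the assay rather than a number.
Compound 2, `Nc1ccc2c(c1)/C(=C(/Nc1ccc(CN3CCCCC3)cc1)c1ccccc1)C(=O)N2`: in this assay compound 2 gives > 6 uM, again a limit.
Compound 3, `CC(=O)N1C(=O)/C(=C(\Nc2ccc(CN3CCCCC3)cc2)c2ccccc2)c2cc(N)ccc21`: in this assay compound 3 gives 1.81 uM.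

Compound 3 is thus the only one of the three with an actual number; the other two sit at the limit of > 6 uM in this assay, at which 2 of the 3 values shown sit. Within the data shown here, the single measured step, an at least 3.3-fold lower number from compound 2 to compound 3 (0.52 log units; beyond the scatter), is the change that brought the number down from the limit, and it concerns acetyl in place of hydrogen on the amide-type ring nitrogen.

Compound 4, `CC(=O)N1C(=O)/C(=C(\Nc2ccc(CN3CCCCC3)cc2)c2ccccc2)c2cc([N+](=O)[O-])ccc21`, differs from compound 3 in another place: nitro in place of amino on an aromatic carbon. Among the measured compounds shown here, no measured step touches this exchange, since the acetyl step is the only one and it lies elsewhere in the molecule. With nothing to point in either direction, the number for compound 4 is expected to stay close to that of compound 3, with the range kept wide to reflect the lack of any comparable pair. Compound 4 is therefore estimated at 2.2 uM, between 0.7 uM and 7 uM. The step of a 1.2-fold higher number from compound 3 to compound 4 (0.08 log units; within the scatter) is accordingly expected to remain within the scatter.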

Compound 4, half-maximal toxic concentration: > 6 uM
Compound 4: a limit, no number; the forecaster's own chance of this, stated with the estimate: 35%; middle value at least 2.7-fold (0.43 log units) away from the limit.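

On this aromatic carbon, with the acetyl group on the ring nitrogen kept in place, putting nitro in place of amino gives an at least 3.3-fold higher number from compound 3 to compound 4 (0.52 log units; beyond the scatter) in this assay. Among these compounds, the earlier step concerned only the ring nitrogen, so this is the first sign that the group on the aromatic carbon also bears on the number, and that the acetyl group alone does not fix the number seen for compound 3. Among the compounds shown here, compound 4 gives a limit of the assay and not a number, which places it with the other compounds at that limit and leaves compound 3 as the only one with an actual number: the limit of > 6 uM in this assay, at which 3 of the 4 values shown sit.

On these data alone, how far the number of compound 4 lies from that of compound 3 stays open, since the step is itself bounded by the limit. Also open, as far as these compounds go, are whether a methoxy group or a chlorine atom on this aromatic carbon would behave like amino or like nitro, and whether nitro has the same effect where the ring nitrogen carries hydrogen instead of acetyl.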